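Swapping the Amide Nitrogen Group: Cyclohexyl to Chlorophenyl

The source may hold more compounds than are shown below. What is called first, only, known or untested is meant among the compounds shown, and "the series" means these compounds.

Compound 1 `CC(=O)Oc1ccc(-c2ccc(F)cc2F)cc1C(=O)NC1CCCCC1`: 15.6%
Compound 2 `CC(=O)Oc1ccc(-c2ccc(F)cc2F)cc1C(=O)NCc1ccccc1`: 16.6%

Of the compounds shown here, two have so far been measured in a functional assay on the whole organism (strain Kunming) for inhibition, with Mus musculus as the target, in the writhing test, at a dose of 40 mg/kg by the oral route; on this read-out higher numbers stand for more inhibition at the one dose given (going by the name of the read-out) and lower numbers for less inhibition. On the bare numbers compound 1 sits at the lower of the two values, yet the step of a number 1 percentage points higher from compound 1 to compound 2 (within the scatter) is within the scatter, so nothing separates compound 1 from compound 2: swapping the cyclohexyl group on the amide nitrogen for a benzyl group left the read-out unchanged.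

The next compound, compound 3 `CC(=O)Oc1ccc(-c2ccc(F)cc2F)cc1C(=O)Nc1ccccc1Cl`, carries the change (2-chlorophenyl in place of cyclohexyl on an amide-type nitrogen). Going by the values given here, the only measured step that bears on this is the one from compound 1 to compound 2, where a group containing an aromatic ring replaced the same cyclohexyl group without any effect beyond the scatter. Among the compounds with values here, no compound yet shows an aromatic ring attached directly to the amide nitrogen, so that part of the change is untested. Given the one step available, the step of a number 1.4 percentage points higher from compound 1 to compound 3 (within the scatter) is expected to be no larger than the scatter. Compound 3 is therefore estimated to give 17%, within a range of 7% to 30%.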

Compound 3, a percentage reported as inhibition, in the whole organism at one dose (the size of the read-out at that dose, not a potency): 11.7%
Estimate against measurement, compound 3: 5.3 percentage points above; low and high end bracket the measured number.
By their numbers in this assay, from the lowest: compounds 3, 1 and 2 (each within the scatter of the next).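

An aromatic ring now sits directly on the amide nitrogen, and in this assay this gives a number 3.9 percentage points lower from compound 1 to compound 3 (within the scatter), while replacing the benzyl group with 2-chlorophenyl gives a number 4.9 percentage points lower from compound 2 to compound 3 (within the scatter). This position has therefore now carried a non-aromatic ring, an aromatic ring held on a single carbon and a chlorine-bearing aromatic ring attached directly, and this single-dose read-out does not tell the three groups apart. No measurement available here explains why these three groups cannot be separated.

From the compounds shown here alone, the part played by the chlorine remains open, since a plain phenyl group on the same nitrogen would be needed to compare directly with 2-chlorophenyl. Also open, going by these compounds, is whether any group at this position can move the read-out beyond the scatter, for example a chain ending in an amine or a carboxylic acid, which would differ more sharply from the three ring groups seen so far.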